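Swapping acetyl for dimethylamino on compound 1

The source may hold more compounds than are shown below. What is called first, only, known or untested is meant among the compounds shown, and "the series" means these compounds.

Measured compounds in a functional assay on UO-31 cells (Homo sapiens) for cytotoxicity, read by sulforhodamine B assay, with a stated time of 48 h, tested at 10 uM; a higher number here means a weaker effect of the compound at the concentration tested, a lower number a stronger effect:
- compound 1 `COc1cc(C)cc(-c2c(-c3ccnc(-c4ccc(C(C)=O)cc4)c3)cnn2CC#N)c1`: 15%
- compound 2 `COc1cc(C)cc(-c2nn(CC#N)cc2-c2ccc(-c3cccc(C(C)=O)c3)nc2)c1`: -6%
- compound 3 `Cc1cc(O)cc(-c2nn(CC#N)cc2-c2ccnc(-c3ccc(Oc4ccccc4)cc3)c2)c1`: -81%

Compound 1 stands highest of the three numbers in this assay, which means the weakest effect of the set at the concentration tested. Compound 2 lies nearest, a number beyond the scatter below it, and compound 3 lies furthest, far below it. The three compounds differ in several places at once, so the values show only where each stands, not what any single change does.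

Compound 4 `COc1cc(C)cc(-c2c(-c3ccnc(-c4ccc(N(C)C)cc4)c3)cnn2CC#N)c1` is not yet measured. It differs from compound 1 in one place: dimethylamino in place of acetyl on an aromatic carbon. Going by the values given here, no pair among the measured compounds isolates this change, so there is no measured step to lean on. Given that compound 1 already sits at the weak end, a shift toward a stronger effect is plausible but by no means assured; the step from compound 1 to compound 4 is expected to be a number 15 percentage points lower from compound 1 to compound 4 (beyond the scatter), small relative to the spread of the set and with wide uncertainty. Compound 4 is therefore estimated at 0%, with a range from -45% to 30%.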

Compound 4, a percentage reported as activity, at one concentration (the size of the read-out at that concentration, not a potency): 7%
Estimate against measurement, compound 4: 7 percentage points below; measured number inside the range.
By their numbers in this assay, from the lowest: compound 3; then compound 2; then compounds 4 and 1 (each within the scatter of the next).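

In this assay, going by these compounds alone, the swap of 4-acetylphenyl to 4-(dimethylamino)phenyl gives a number 8 percentage points lower from compound 1 to compound 4 (within the scatter) and is the first single change that can be read in this set. At this position, on an aromatic carbon para to a large group, a carbonyl-bearing group and a nitrogen-bearing group therefore cannot be told apart at the concentration tested. Nothing at hand accounts for this result.

On these data alone, whether a carboxylic acid, a morpholine or a longer amine chain at this position would move the number beyond the scatter remains open. The compounds shown also leave open whether the same swap of acetyl for dimethylamino would read alike on the core of compound 2, where the acetyl stands on a differently arranged framework.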